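The source may hold more compounds than are shown below. What is called first, only, known or untested is meant among the compounds shown, and "the series" means these compounds.

Measured compounds:
Compound 1 `CC1=C(C(=O)OC(C)C)[C@@H](c2ccco2)N/C(=N/C#N)N1`: 4%
Compound 2 `CC1=C(C(=O)OC(C)C)C(c2ccsc2)N/C(=N/C#N)N1`: 13%

In an assay on HeLa cells for displacement of a labelled ligand from adenosine receptor A3 (Homo sapiens), with a stated time of 180 min, tested at 1 uM (on this read-out higher numbers stand for more inhibition at the one concentration tested (going by the name of the read-out) and lower numbers for less inhibition), compound 2 gives 13%, the higher of the two numbers shown, while compound 1 gives 4%, a gap that lies within the usual scatter. Compound 3 `CC1=C(C(=O)OC(C)C)C(c2ccco2)N/C(=N/C#N)N1` differs from compound 2 by furan-2-yl in place of thiophen-3-yl on a saturated ring carbon. No measured step of this kind exists among these compounds. The step of a number 7 percentage points lower from compound 2 to compound 3 (within the scatter) is expected to be small and downward, or none beyond the scatter, because compound 1 gives 4% with the same entering group. Compound 3 is therefore estimated at 6%, with a range from 0% to 15%.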

Compound 3, a percentage reported as inhibition, at one concentration (the size of the read-out at that concentration, not a potency): 4%
The estimate for compound 3 lay 2 percentage points above the measured number, within the range that was stated.
By their numbers in this assay, from the lowest: compounds 1, 3 and 2 (each within the scatter of the next).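

In this assay, exchanging one five-membered aromatic ring for another on the saturated ring carbon gives a number 9 percentage points lower from compound 2 to compound 3 (within the scatter), so furan-2-yl and thiophen-3-yl cannot be told apart at this position. Defining the stereocentre at that carbon gives no change at the digits printed from compound 1 to compound 3 (within the scatter), which is also the first reading of a stereo change here, and the sole difference in that pair is this: the fact that one of compounds 1 and 3 is drawn with a defined configuration and the other without, at the place where they differ

From the compounds shown here alone, it remains open whether a group of another kind on this carbon, such as a phenyl ring or an aminomethyl group, would give a step beyond the scatter. Going by these compounds, the opposite configuration, drawn on its own, also remains open.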